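Triazole substituent pruned to hydrogen in the antiproliferation series

The source may report more compounds than this note shows. Statements on the series, on what has been measured and on what is new or still open speak of the compounds shown alone.

In a functional assay on SW-620 cells (Homo sapiens) for antiproliferative activity, read by MTT assay, with a stated time of 72 h (a higher number here means a weaker inhibitor, a lower number a stronger inhibitor), compound 2 `O=C1O[C@H]([C@@H](O)Cn2cc(CNS(=O)(=O)c3ccc(Cl)cc3)nn2)C(OCc2ccccc2)=C1OCc1ccccc1` gives 18000 nM, the higher of the two numbers measured, since compound 1 `O=C1O[C@H]([C@@H](O)Cn2cc(-c3ccc(Br)cc3)nn2)C(OCc2ccccc2)=C1OCc1ccccc1` gives 3760 nM. Going by the values given here, the one measured step is a 4.8-fold higher number from compound 1 to compound 2 (0.68 log units; beyond the scatter). Compound 3 `O=C1O[C@H]([C@@H](O)Cn2ccnn2)C(OCc2ccccc2)=C1OCc1ccccc1` carries hydrogen in place of (((4-chlorophenyl)sulfonyl)amino)methyl on an aromatic carbon. Among the compounds with values here, no measured pair shows what a bare hydrogen at that position does, so the step from compound 1 to compound 2 bears only loosely. Removing the group that accompanied the weaker number is expected to move the number down somewhat, by a 2.0-fold lower number from compound 2 to compound 3 (0.30 log units; within the scatter), with wide uncertainty. For compound 3 in this assay the estimate is 9000 nM, ranging from 2500 nM to 30000 nM.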

Compound 3, half-maximal inhibitory concentration: > 100000 nM
Compound 3 gave a limit, no number; the forecaster's own chance of this, stated with the estimate: 15%; middle value at least 11-fold (1.04 log units) from the limit.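

Compound 3 gave a limit in this assay, not a number: the limit of > 100000 nM in this assay, at which 1 of the 3 values shown sits. Removing either group weakens the compound, with an at least 5.5-fold higher number from compound 2 to compound 3 (0.74 log units; beyond the scatter) and an at least 26-fold higher number from compound 1 to compound 3 (1.42 log units; beyond the scatter). Among these three compounds, a substituent on this aromatic carbon therefore goes with measurable antiproliferative activity, whereas the earlier pair only ranked 4-bromophenyl ahead of (((4-chlorophenyl)sulfonyl)amino)methyl.

The limit leaves the full size of both steps open. Going by these compounds, whether a small group such as a methyl, an amine or a carboxylic acid on this carbon would be enough to restore activity also remains open.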